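A Methoxy for Chloro at the Assay Limit

The source may report more compounds than this note shows. Statements on the series, on what has been measured and on what is new or still open speak of the compounds shown alone.

Compound 1 (`OCc1cn(Cc2ccc(Cl)cc2)c2ccccc12`) offers no exact starting number in an ADME assay on T29 cells (Homo sapiens) for cytotoxicity, read by sulforhodamine B assay, with a stated time of 3 days; a higher number here means a weaker inhibitor, a lower number a stronger inhibitor. In this assay compound 1 gives > 31600 nM as a limit of the assay and not a number. Compound 2 (`OCc1cn(Cc2cccc(C(F)(F)F)c2)c2ccccc12`) gives > 31600 nM as a limit too. Among the measured compounds shown here, compound 1 and compound 2 both rest on the limit of > 31600 nM in this assay, at which 2 of the 2 values shown sit, and neither supplies a measured value, so no measured step between them is available as a guide.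

Compound 3 (`COc1ccc(Cn2cc(CO)c3ccccc32)cc1`) keeps the core of compound 1 and has methoxy in place of chloro on an aromatic carbon, para to a large group (methoxy in place of chloro on an aromatic carbon) . With compound 1 and compound 2 both resting on (the limit of > 31600 nM in this assay, at which 2 of the 2 values shown sit), no step beyond the scatter is expected in this assay in either direction. The estimated change is a step that the limit leaves unreadable from compound 1 to compound 3 and it carries the uncertainty of a starting point that is only a limit. For compound 3 the expected value is 40000 nM with an estimated range from 15000 nM to 100000 nM and a report of only a limit is the likeliest outcome.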

Compound 3, half-maximal inhibitory concentration: > 31600 nM
Compound 3 gave a limit, no number (the forecaster's own chance of this, stated with the estimate: 80%); the middle value lies beyond the limit too.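

In this assay compound 3 gives > 31600 nM, a limit of the assay and not a number. Among the compounds shown here, no step from compound 1 to compound 3 can be read, because both rest on a limit: the limit of > 31600 nM in this assay, at which 3 of the 3 values shown sit. The compounds shown leave open whether any of them has a measurable half-maximal inhibitory concentration in this assay, and so how methoxy and chloro compare there.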